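Para-chloro analogue of an inactive pair in the rat stomach assay

The source may report more compounds than this note shows. Statements on the series, on what has been measured and on what is new or still open speak of the compounds shown alone.

Compound 1, `N=C(S)CCN1N=C(c2ccc(Cl)c(Cl)c2)CCC1=O`: in a functional assay on the whole organism (stomach) with Rattus norvegicus as the target (a lower number here means that less compound is needed, a higher number that more compound is needed for the effect), compound 1 gives > 100 mg/kg, which is a limit of the assay rather than a number.
Compound 2, `N=C(S)CCN1N=C(c2ccccc2)CCC1=O`: in this assay compound 2 gives > 100 mg/kg, again a limit of the assay.

Both measured values therefore sit at the same limit, as the limit of > 100 mg/kg in this assay, at which 2 of the 2 values shown sit, records, and compound 2 stands there with no number of its own. Compound 3, `N=C(S)CCN1N=C(c2ccc(Cl)cc2)CCC1=O`, differs from compound 2 by chloro in place of hydrogen on an aromatic carbon. Among the measured compounds shown here, no measured step between compounds exists here, so the size of this change cannot be read from a neighbouring pair; with compound 1 and compound 2 both at the limit, nothing points to a move beyond the scatter in either direction. Compound 3 is therefore expected to give 150 mg/kg (range 60 mg/kg to 400 mg/kg), and the step that the limit leaves unreadable from compound 2 to compound 3 is expected to be essentially none, with the assay most likely returning a limit again.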

Compound 3, dose for half-maximal effect: > 100 mg/kg
Compound 3: only a limit was reported (the forecaster's own chance of this, stated with the estimate: 80%); the middle value is on the limit's open side.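

In this assay compound 3 gives > 100 mg/kg, which is a limit of the assay. Among the compounds shown here, no step among compound 1, compound 2 and compound 3 can be read. The compounds shown leave open whether chloro in place of hydrogen on an aromatic carbon changes the dose needed at all: the limit of > 100 mg/kg in this assay, at which 3 of the 3 values shown sit.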